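A few compounds are considered here, and "the series" means these few. Any claim that something is new, unique, unknown or untested is made for them only; others in the source may bear on it.

Working notes on the series, read in a functional assay on HCT-116 cells (Homo sapiens) for antiproliferative activity, with a stated time of 72 h; a higher number here means a weaker inhibitor, a lower number a stronger inhibitor. Compound 1 `CC(=O)Oc1ccccc1/C=C/c1nc(Nc2ccccc2I)c2ccccc2n1` gives only a limit, > 25000 nM. Compound 3 `COc1ccccc1/C=C/c1nc2ccccc2c(=O)[nH]1` gives 1460 nM. Compound 2 `COc1ccccc1/C=C/c1nc(Nc2ccccc2Cl)c2ccccc2n1` gives 16100 nM, the higher of the two actual numbers in hand, and its gap to compound 3 lies beyond the scatter.

The next compound to read is compound 4 `COc1ccccc1/C=C/c1nc(Nc2ccc(O)cc2)c2ccccc2n1`. It has 4-hydroxyphenyl in place of 2-chlorophenyl on a nitrogen on an aromatic ring. Among the measured compounds shown here, no measured pair isolates this kind of change, so the expectation rests on thin ground and the range is kept wide.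

A moderate fall in this assay is expected, because compound 2 at 16100 nM leaves little room upward. The expected size of the change is a 5.4-fold lower number from compound 2 to compound 4 (0.73 log units; beyond the scatter), which would lie beyond the scatter if the estimate holds. Compound 4 is estimated at 3000 nM, with an expected range of 600 nM to 15000 nM.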

Compound 4, half-maximal inhibitory concentration: 17900 nM
For compound 4 the middle estimate is 6.0-fold (0.78 log units) below the measured one; the measured number lies above the stated range.
By their numbers in this assay, from the lowest: compound 3; then compounds 2 and 4 (each within the scatter of the next). At a limit, above all of these: compound 1.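

In this assay, among the compounds shown here, this is the first measured pair at this place, and it gives a 1.1-fold higher number from compound 2 to compound 4 (0.05 log units; within the scatter), with 4-hydroxyphenyl in place of 2-chlorophenyl on a nitrogen on an aromatic ring. The hydrogen-bond donor and acceptor that enter with 4-hydroxyphenyl therefore leave the reading within the scatter, so this one exchange does not separate the two groups. Compound 1 gives only a limit, not a number, and so offers no measured step at this place: the limit of > 25000 nM in this assay, at which 1 of the 4 values shown sits.

For the compounds shown here, the single pair changes both the substituent on the phenyl ring and its printed ring position, so the effects of the two cannot be told apart. Going by these compounds, how an aminophenyl or carboxyphenyl group, or a longer alkyl chain on that nitrogen, would read remains open.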